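Replacing 3,4-dihydroxyphenyl with 3,4-dimethoxyphenyl in compound 2

This account rests on a few compounds, and the source may have more. Where it says the series, first, only, none or still open, it means among the compounds named here.

Compound 1 `COc1ccc(/C=C/C(=O)OCCCCOc2cc(Cl)ccc2Oc2ccc(Cl)cc2Cl)cc1OC`: 73400 nM
Compound 2 `O=C(/C=C/c1ccc(O)c(O)c1)OCCCCCCCCCOc1cc(Cl)ccc1Oc1ccc(Cl)cc1Cl`: 3620 nM

In an ADME assay on U-937 cells (Homo sapiens) for cytotoxicity, read by MTT assay, with a stated time of 72 h (a higher number here means that more compound is tolerated, a lower number that less compound is tolerated), compound 2 gives 3620 nM, the lower of the two numbers, and the gap to compound 1, which gives 73400 nM, lies beyond the scatter. Compound 3 `COc1ccc(/C=C/C(=O)OCCCCCCCCCOc2cc(Cl)ccc2Oc2ccc(Cl)cc2Cl)cc1OC` awaits measurement. It has 3,4-dimethoxyphenyl in place of 3,4-dihydroxyphenyl on a double-bonded chain carbon bound to a double-bonded chain carbon. Compound 1 carries the same 3,4-dimethoxyphenyl and gives 73400 nM, but it also differs from compound 2 elsewhere, so it offers only a loose guide. A moderate rise beyond the scatter is expected, an estimated 3.9-fold higher number from compound 2 to compound 3 (0.59 log units; beyond the scatter). For compound 3 the expected value is 14000 nM, with an estimated range of 4500 nM to 45000 nM.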

Compound 3, concentration lethal to 50% of the cells: 107000 nM
The estimate for compound 3 lay 7.6-fold (0.88 log units) below the measured number, and the stated range ends below it.
By their numbers in this assay, from the lowest: compound 2; then compounds 1 and 3 (each within the scatter of the next).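

In this assay, putting 3,4-dimethoxyphenyl in place of 3,4-dihydroxyphenyl on a double-bonded chain carbon bound to a double-bonded chain carbon, with the rest of the structure unchanged, gives a 30-fold higher number from compound 2 to compound 3 (1.47 log units; beyond the scatter). Within the data shown here, this is the first reading of this change on its own, as compound 1 and compound 2 differ in more than one place. Nothing measured here accounts for the step. The compounds shown leave open whether a phenyl carrying one hydroxy and one methoxy group would sit nearer compound 2 or compound 3. They also leave open whether the same change gives a step of this size on a shorter chain.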